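From a Silyl Alkyne to a Hexyl Chain

This account rests on a few compounds, and the source may have more. Where it says the series, first, only, none or still open, it means among the compounds named here.

Compound 2 `CC(=O)Nc1nc(-c2cccc(NS(=O)(=O)c3ccc(C#C[Si](C)(C)C)cc3)c2)cs1` holds the higher of the two numbers measured in a functional assay on A-375 cells (Homo sapiens) for antiproliferative activity, read by trypan blue exclusion, with a stated time of 48 h, tested at 1 uM (on this read-out lower numbers stand for a stronger effect and higher numbers for a weaker effect at the one concentration tested), where compound 2 gives 94.3%. Its nearest neighbour, compound 1 `CC(=O)Nc1nc(-c2cccc(NS(=O)(=O)c3ccc(C#CCO)cc3)c2)cs1`, gives 81.3% in this assay, and the step of a number 13 percentage points higher from compound 1 to compound 2 (beyond the scatter) lies beyond the scatter, so compound 2 shows the weaker effect of the pair. Compound 3 `CCCCCCc1ccc(S(=O)(=O)Nc2cccc(-c3csc(NC(C)=O)n3)c2)cc1` has not been measured; it differs from compound 2 in one place: a group of 6 heavy atoms (6 carbon; no ring) in place of a group of 6 heavy atoms (5 carbon, 1 silicon; no ring), on an aromatic carbon. For the measured compounds named here, the only measured step, a number 13 percentage points higher from compound 1 to compound 2 (beyond the scatter), also swaps a group on a triple-bonded carbon, yet both compounds of that step keep the triple bond, whereas compound 3 has none, so that step bears on the present change only loosely. With so little to go on, the expected step of a number 6.3 percentage points lower from compound 2 to compound 3 (within the scatter) is small and within the scatter. Compound 3 is therefore estimated at 88%, with a range from 70% to 100%.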

Compound 3, a percentage reported as activity, at one concentration (the size of the read-out at that concentration, not a potency): 49.9%
Compound 3: the middle estimate sits 38.1 percentage points above what was measured; measured number below the stated range.
By their numbers in this assay, from the lowest: compound 3; then compound 1; then compound 2.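

In this assay, hexyl brings a number 44.4 percentage points lower from compound 2 to compound 3 (beyond the scatter), even though the group that leaves and the group that enters hold the same number of heavy atoms, so that count alone does not settle the read-out at this position. Set against the other alkyne, hexyl brings a number 31.4 percentage points lower from compound 1 to compound 3 (beyond the scatter), a much larger step than the one between the two alkynes, and compound 3 shows the strongest effect of the three at the one concentration tested. Nothing available here explains why this change has so large an effect.

The compounds shown leave open whether the stronger effect goes with the loss of the triple bond or with the hexyl chain itself. A hex-1-yn-1-yl group would test the triple bond, while a butyl or octyl chain would test the chain length.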